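This account rests on a few compounds, and the source may have more. Where it says the series, first, only, none or still open, it means among the compounds named here.

Of the compounds shown here, three of a shared core have been measured in an ADME assay on the whole organism (Rattus norvegicus) for pharmacokinetics, using cassette dosing, at a dose of 1 mg/kg by the oral route; a lower number here means that a smaller share of the oral dose reaches the circulation, a higher number that a larger share of the oral dose reaches the circulation. Compound 1 `C[C@@H](Cn1c(=O)[nH]/c(=N\c2ccc(Oc3nccs3)cc2)n(Cc2ccc(Cl)cc2)c1=O)C(=O)O` gives 41.4% in this assay, the lowest of the three numbers. Compound 2 `CC(C)Oc1ccc(/N=c2\[nH]c(=O)n(CC(C)(C)C(=O)O)c(=O)n2Cc2ccc(Cl)cc2)cc1Cl` gives 85.3% in this assay, and compound 3 `Cc1cc(/N=c2\[nH]c(=O)n(C[C@H](C)C(=O)O)c(=O)n2Cc2ccc(Cl)cc2)ccc1OC(C)C` gives 102%. Both of those numbers lie well above the number for compound 1, beyond the scatter of repeated measurements. Compound 1 therefore stands clearly at the bottom of the group.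

Compound 4 `C[C@@H](Cn1c(=O)[nH]/c(=N\c2ccc(Oc3ccnc(F)c3)cc2)n(Cc2ccc(Cl)cc2)c1=O)C(=O)O` has not yet been measured. It differs from compound 1 in one place only: 2-fluoropyridin-4-yl in place of 1,3-thiazol-2-yl on an oxygen on an aromatic ring. For the measured compounds named here, no pair of measured compounds differs by this same change, so nothing already measured tells how large the effect will be. The change keeps the core and the carboxylic acid side chain untouched and only swaps the ring on the oxygen.

Compound 4 is expected to land a little higher than compound 1, with an expected step of a number 10.6 percentage points higher from compound 1 to compound 4 (beyond the scatter) that may or may not exceed the scatter. The estimate for compound 4 in this assay is 52%, within a range from 28% to 80%.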

Compound 4, oral bioavailability: 43.2%
Estimate against measurement, compound 4: 8.8 percentage points above; the range from low to high includes it.
By their numbers in this assay, from the lowest: compounds 1 and 4 (each within the scatter of the next); then compound 2; then compound 3.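

Measured in this assay, replacing 1,3-thiazol-2-yl with 2-fluoropyridin-4-yl on the oxygen gives a number 1.8 percentage points higher from compound 1 to compound 4 (within the scatter) and so separates the two compounds by no more than repeat measurements would. At this position on the shared core, a five-membered aromatic ring with two hetero atoms can therefore give way to a six-membered one carrying fluorine with no readable effect on oral bioavailability. Nothing at hand explains why these two rings read alike.

On these data alone, it remains open whether this position is insensitive in general or whether these two rings merely happen to match, as a pyridine ring without the fluorine, a plain phenyl ring or a chain ending in an amine on the same oxygen could show. As far as these compounds go, whether the same swap would read alike with a different side chain on the core also remains unknown.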